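Aryl swap on the ring nitrogen: compound 3 to compound 4

The compounds below may be only part of what the source reports. "The series", "measured", "known", "first", "only" and "open" are said of these compounds alone.

Measured so far:
- compound 1 `O=c1[nH]cc(S(=O)(=O)Nc2ccccc2-c2cn(-c3ccccc3F)nn2)c(=O)[nH]1` gives 7370 nM in a functional assay on A549 cells (Homo sapiens) for antiproliferative activity, read by MTT assay, with a stated time of 24 h; a lower number here means a stronger inhibitor, a higher number a weaker inhibitor
- compound 2 `O=c1[nH]cc(S(=O)(=O)Nc2ccccc2-c2cn(-c3cccc(Cl)c3)nn2)c(=O)[nH]1` gives 2340 nM in this assay
- compound 3 `Cc1ccccc1-n1cc(-c2cccc(NS(=O)(=O)c3c[nH]c(=O)[nH]c3=O)c2)nn1` gives 5470 nM in this assay

Compound 3 holds the second highest of the three numbers. Its nearest neighbour is compound 1, within the scatter, so no order between the two can be read; compound 2 sits furthest from it, beyond the scatter.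

Compound 4 `O=c1[nH]cc(S(=O)(=O)Nc2cccc(-c3cn(-c4cccc(F)c4)nn3)c2)c(=O)[nH]1` shares the core of compound 3 and differs by 3-fluorophenyl in place of 2-methylphenyl on an aromatic nitrogen. Among the measured compounds shown here, the only measured step on the group at this ring nitrogen is a 3.1-fold lower number from compound 1 to compound 2 (0.50 log units; beyond the scatter), which lies on the core shared by compound 1 and compound 2, not on that of compound 3, and exchanges a different pair of groups. It shows that a change of the aryl group on this nitrogen can shift the number modestly and downward.

Taking that as the sole guide, compound 4 is expected to move by a 1.4-fold lower number from compound 3 to compound 4 (0.14 log units; within the scatter), a small step that may stay within the scatter. Compound 4 is therefore estimated at 4000 nM, with a range from 1500 nM to 10000 nM.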

Compound 4, half-maximal inhibitory concentration: 7200 nM
Beside the measured number, compound 4's estimate is 1.8-fold (0.26 log units) below it; measured number inside the range.
By their numbers in this assay, from the lowest: compound 2; then compounds 3, 4 and 1 (each within the scatter of the next).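

On the core of compound 3, exchanging 2-methylphenyl for 3-fluorophenyl on the aromatic nitrogen gives a 1.3-fold higher number from compound 3 to compound 4 (0.12 log units; within the scatter) in this assay, so no difference between these two groups can be read at this position. Both groups have the same heavy-atom count and a single six-membered aromatic ring of carbon only, and neither has a hydrogen-bond donor or acceptor. Among the compounds shown here, the only step beyond the scatter at this nitrogen remains a 3.1-fold lower number from compound 1 to compound 2 (0.50 log units; beyond the scatter), which lies on a different core and involves a different pair of groups, while no measurement here offers an explanation for either step.

On these data alone, it remains open whether 3-chlorophenyl would give a step beyond the scatter on the core of compound 3. Also open, as far as these compounds go, is how this assay would respond to a less similar group on the nitrogen, such as a phenyl ring bearing an amine or a carboxylic acid, or a longer chain replacing the aryl group.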